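Replacing furan-2-yl in compound 3: a cytotoxicity estimate

This account rests on a few compounds, and the source may have more. Where it says the series, first, only, none or still open, it means among the compounds named here.

Measured in an ADME assay on MT4 cells (Homo sapiens) for cytotoxicity, read by MTT assay; on this read-out lower numbers stand for higher toxicity in this test and higher numbers for lower toxicity in this test
Compound 1 `Cc1cc(C)cc(S(=O)(=O)c2c(C(=O)NCC(=O)NCc3ccco3)[nH]c3ccc(Cl)cc23)c1` gives > 50000 nM
Compound 2 `Cc1cc(C)cc(S(=O)(=O)c2c(C(=O)NCc3n[nH]c4ccccc34)[nH]c3ccc(Cl)cc23)c1` gives > 50700 nM
Compound 3 `Cc1cc(C)cc(S(=O)(=O)c2c(C(=O)NC(C)c3ccco3)[nH]c3ccc(Cl)cc23)c1` gives > 54700 nM

Compound 3 stands at > 54700 nM as a limit and not as a number. The values of compound 1 and compound 2 are limits too, so none of the three compounds has a measured number.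

In compound 4 `Cc1cc(C)cc(S(=O)(=O)c2c(C(=O)NC(C)C(=O)NCc3ccccc3F)[nH]c3ccc(Cl)cc23)c1`, (2-fluorobenzyl)carbamoyl stands in place of furan-2-yl on a saturated chain carbon bound to an amide-type nitrogen and a saturated chain carbon (2-fluorobenzyl)carbamoyl in place of furan-2-yl on a saturated chain carbon bound to an amide-type nitrogen and a saturated chain carbon and the rest of the structure stays the same.

The measured steps that bear on this are a step that the two limits leave unreadable from compound 1 to compound 3 and a step that the two limits leave unreadable from compound 1 to compound 2 as well as a step that the two limits leave unreadable from compound 2 to compound 3 and none of them gives a size. Compound 4 is therefore expected to reach a limit as well, with no step beyond the scatter foreseen in this assay in either direction. The expected change is an at least 1.1-fold lower number from compound 3 to compound 4 (0.07 log units; that floor lies within the scatter) in this estimate. Compound 4 is estimated at 46000 nM and expected to fall from 25000 nM to 60000 nM as its range.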

Compound 4, half-maximal cytotoxic concentration: 23300 nM
Estimate against measurement, compound 4: 2.0-fold (0.30 log units) above, outside the stated range (below it).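

In this assay, among these compounds, putting (2-fluorobenzyl)carbamoyl in place of furan-2-yl on this saturated chain carbon gives an at least 2.3-fold lower number from compound 3 to compound 4 (0.37 log units; beyond the scatter), and this is the only step here that can be read, since the steps among the earlier compounds cannot. It shows that a change at this place can bring a measurable toxicity into this test, which compounds sitting only at limits could not show. Compound 3 has only a limit, so this step is a floor and not a full size: the limit of > 54700 nM in this assay, at which 1 of the 4 values shown sits.

The compounds shown do not separate the part played by the carbamoyl from that of the 2-fluorobenzyl, as both enter together. Also open, as far as these compounds go, is how this assay would respond to a plain benzyl amide, a carboxylic acid or an amine on this carbon.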